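This account rests on a few compounds, and the source may have more. Where it says the series, first, only, none or still open, it means among the compounds named here.

Measured compounds:
compound 1 `O=C(O)c1ccc(-c2cnc(C(=O)CCCCCCc3ccccc3)o2)cc1` — 60 nM
compound 2 `NC(=O)c1ccc(-c2cnc(C(=O)CCCCCCc3ccccc3)o2)cc1` — 10 nM
compound 3 `O=C(CCCCCCc1ccccc1)c1ncc(-c2ncccc2C(=O)O)o1` — > 50 nM

In an assay (Rattus norvegicus) for inhibition of Fatty-acid amide hydrolase 1 (Homo sapiens) (on this read-out lower numbers stand for stronger inhibition and higher numbers for weaker inhibition), compound 3 is known only by a limit, > 50 nM, which is where it stands (the limit of > 50 nM in this assay, at which 1 of the 3 values shown sits). Compound 4 `O=C(CCCCCCc1ccccc1)c1ncc(-c2ccncn2)o1` differs from compound 3 by pyrimidin-4-yl in place of 3-carboxypyridin-2-yl on an aromatic carbon. Among the measured compounds shown here, two measured steps bear on this exchange at the same aromatic carbon: a 6.0-fold lower number from compound 1 to compound 2 (0.78 log units; beyond the scatter) and an at least 5.0-fold higher number from compound 2 to compound 3 (0.69 log units; beyond the scatter). Neither pairs a carboxylic acid with a group that lacks a donor, so the direction of the step to compound 4 in this assay rests on a thin basis. Compound 4 is expected to give 60 nM, with a range from 15 nM to 300 nM. That estimate means a step that the limit leaves unreadable from compound 3 to compound 4, read against the limit of compound 3.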

Compound 4, inhibition constant: 2.3 nM
Compound 4: the middle estimate sits 26-fold (1.42 log units) above what was measured; the measured number lies below the stated range.
By their numbers in this assay, from the lowest: compound 4; then compound 2; then compound 1.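

In this assay, a hydrogen-bond donor on the ring at the aromatic carbon next to the ring oxygen is not required: pyrimidin-4-yl, with 0 hydrogen-bond donors, gives a 4.3-fold lower number from compound 2 to compound 4 (0.64 log units; beyond the scatter) and a 26-fold lower number from compound 1 to compound 4 (1.42 log units; beyond the scatter). In place of 3-carboxypyridin-2-yl, it gives an at least 21-fold lower number from compound 3 to compound 4 (1.33 log units; beyond the scatter), a step read against a limit: the limit of > 50 nM in this assay, at which 1 of the 4 values shown sits.

Open, from the compounds shown here alone, is whether an unsubstituted phenyl or a pyridin-2-yl at this carbon would reach the same level. Such a group would separate the contribution of the ring nitrogens from the removal of the carboxylic acid or carboxamide.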